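Moving a fluorine around the ring of compound 1

The source may report more compounds than this note shows. Statements on the series, on what has been measured and on what is new or still open speak of the compounds shown alone.

Measured so far:
- compound 1 `O=C(Nc1cc(-c2ccccn2)n[nH]1)N1CCC(c2ccc(F)cc2)CC1`: 42.5 mL.min-1.g-1
- compound 2 `O=C(NCc1cccc(Cl)c1)Nc1cc(-c2ccccn2)n[nH]1`: 184 mL.min-1.g-1

In an ADME assay on liver for metabolic stability, with Liver microsome (Homo sapiens) as the target, using microsomes (a higher number here means faster removal of the compound, a lower number slower removal), compound 1 gives 42.5 mL.min-1.g-1, the lower of the two numbers; compound 2 gives 184 mL.min-1.g-1, a higher number beyond the usual scatter. Compound 3 `O=C(Nc1cc(-c2ccccn2)n[nH]1)N1CCC(c2cccc(F)c2)CC1` keeps the core of compound 1 and changes only the fluorophenyl group: 3-fluorophenyl in place of 4-fluorophenyl on a saturated ring carbon. Among the measured compounds shown here, no step of this exact kind has been measured, so there is no direct guide, and a shift no larger than the scatter is expected in either direction. The step from compound 1 to compound 3 is estimated at a 1.2-fold higher number from compound 1 to compound 3 (0.07 log units; within the scatter), giving compound 3 an expected 50 mL.min-1.g-1, within 22 mL.min-1.g-1 to 110 mL.min-1.g-1.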

Compound 3, intrinsic clearance in microsomes: 25.3 mL.min-1.g-1
Beside the measured number, compound 3's estimate is 2.0-fold (0.30 log units) above it; the measured number falls inside the stated range.
By their numbers in this assay, from the lowest: compounds 3 and 1 (each within the scatter of the next); then compound 2.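

In this assay the swap to 3-fluorophenyl in place of 4-fluorophenyl on the saturated ring carbon is a small step (a 1.7-fold lower number from compound 1 to compound 3 (0.23 log units; within the scatter)). So moving the fluorine around this phenyl ring, in these two forms, gives no difference that stands clear of repeat-measurement noise, and compound 3 stays level with compound 1. No supporting data bear on this result. Still open, on these data alone, is whether a methoxy group, a nitrile or an amine in place of the fluorine on this phenyl ring would shift the number beyond the scatter.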